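Swapping the aryl group on the amide of compound 1

The compounds below may be only part of what the source reports. "The series", "measured", "known", "first", "only" and "open" are said of these compounds alone.

Compound 1, `COc1cc(Cl)cc(-c2nn(-c3cccc(NC(=O)c4ccc(Cl)c(Cl)c4)c3)cc2-c2ccncc2)c1`, was tested in a functional assay on RXF 393 cells (Homo sapiens) for inhibition, read by sulforhodamine B assay, with a stated time of 48 h, tested at 10 uM (on this read-out lower numbers stand for a stronger effect and higher numbers for a weaker effect at the one concentration tested), where compound 1 gives 59.2%. Among the three measured compounds this is the highest number: compound 3, `COc1cc(Cl)cc(-c2nn(-c3cccc(NC(=O)Nc4cccc(C(F)(F)F)c4)c3)cc2-c2ccncc2)c1`, gives 11.8%, and compound 2, `COc1cc(Cl)cc(-c2nn(-c3cccc(NC(=O)Nc4cc(C(F)(F)F)cc(C(F)(F)F)c4)c3)cc2-c2ccncc2)c1`, gives -29.3%. Both gaps lie beyond the scatter, so compound 1 shows the weakest effect of the three.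

The unmeasured compound 4, `COc1cc(Cl)cc(-c2nn(-c3cccc(NC(=O)c4cccc(C(F)(F)F)c4)c3)cc2-c2ccncc2)c1`, differs from compound 1 in one place: 3-(trifluoromethyl)phenyl in place of 3,4-dichlorophenyl on a carbonyl carbon. The aryl group on the carbonyl is exchanged while the amide link is kept.

Within the data shown here, no measured step isolates exactly this exchange. The nearest is a number 47.4 percentage points lower from compound 1 to compound 3 (beyond the scatter), but that step replaces the aryl group and at the same time inserts an extra amino link, turning the amide into a urea. The step of a number 41.1 percentage points higher from compound 2 to compound 3 (beyond the scatter) concerns only the urea pair and shows that taking away one trifluoromethyl raises the number a great deal. Since compound 4 keeps the amide link, only part of the drop seen from compound 1 to compound 3 is expected to carry over, with the direction downward. The step from compound 1 to compound 4 is therefore estimated at a number 24.2 percentage points lower from compound 1 to compound 4 (beyond the scatter). Compound 4 is expected to give about 35%, within a range from 5% to 62%.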

Compound 4, a percentage reported as activity, at one concentration (the size of the read-out at that concentration, not a potency): 40.5%
Compound 4: the middle estimate sits 5.5 percentage points below what was measured, and the stated range covers the measured number.
By their numbers in this assay, from the lowest: compound 2; then compound 3; then compound 4; then compound 1.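

In this assay the aryl exchange on the carbonyl carbon can now be read on its own: with the amide link kept, 3-(trifluoromethyl)phenyl in place of 3,4-dichlorophenyl gives a number 18.7 percentage points lower from compound 1 to compound 4 (beyond the scatter) and so the aryl group at this position counts by itself. The link can be read on its own as well, since compound 3 and compound 4 carry the same 3-(trifluoromethyl)phenyl and differ only in the amino link of the urea, and losing that link gives a number 28.7 percentage points higher from compound 3 to compound 4 (beyond the scatter) so that the earlier drop from the amide of compound 1 to the urea of compound 3 reflects both changes and not the aryl group alone. Nothing measured here gives a reason for either step.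

From the compounds shown here alone, it remains open whether the second trifluoromethyl of compound 2 would lower the number on the amide link as it does on the urea link. Also open, going by these compounds, is how a cyclohexyl ring or a short chain ending in an amine would read on this carbonyl carbon in place of an aryl group.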